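This account rests on a few compounds, and the source may have more. Where it says the series, first, only, none or still open, it means among the compounds named here.

Within the data shown here, in a functional assay on HepG2 cells (Homo sapiens) for inhibition, read by MTT assay, with a stated time of 72 h (on this read-out lower numbers stand for stronger inhibition and higher numbers for weaker inhibition), compound 3 `COc1ccc(NC(=O)C2CCN(C/C=C/c3ccccc3)CC2)cc1` gives 88800 nM and holds the highest of the three numbers so far. Compound 1 `Cc1ccc(NC(=O)C2CCN(C/C=C/c3ccccc3)CC2)cc1` gives 33900 nM in this test and compound 2 `CCCCCc1ccc(NC(=O)C2CCN(C/C=C/c3ccccc3)CC2)cc1` gives 2890 nM in it. Compound 4 `O=C(Nc1ccc(F)c(Br)c1)C1CCN(C/C=C/c2ccccc2)CC1`, not yet measured, carries 3-bromo-4-fluorophenyl in place of 4-methoxyphenyl on an amide-type nitrogen. Two measured steps bring in methoxy on an aromatic carbon: a 2.6-fold higher number from compound 1 to compound 3 (0.42 log units; beyond the scatter) is modest and a 31-fold higher number from compound 2 to compound 3 (1.49 log units; beyond the scatter) is large. Neither involves the entering group, so this guide is indirect. Leaving methoxy behind is therefore expected to give a modest step to a lower number in this assay here. The expected step is a 4.4-fold lower number from compound 3 to compound 4 (0.65 log units; beyond the scatter) by this estimate. For compound 4 the estimated value is 20000 nM (range 6000 nM to 60000 nM).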

Compound 4, half-maximal inhibitory concentration: 8190 nM
Compound 4: middle estimate off by 2.4-fold (0.39 log units), on the high side; the range from low to high includes it.
By their numbers in this assay, from the lowest: compound 2; then compound 4; then compound 1; then compound 3.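

In this assay the ring on the amide-type nitrogen accepts two halogens, and 3-bromo-4-fluorophenyl gives an 11-fold lower number from compound 3 to compound 4 (1.04 log units; beyond the scatter) and also a 4.1-fold lower number from compound 1 to compound 4 (0.62 log units; beyond the scatter) in the same test. A large step at this position therefore does not depend on the pentyl chain of compound 2. Nothing available explains why this change lowers the number.

Bromine and fluorine enter together, so the share of each stays unknown. Going by these compounds, how an amine or a carboxylic acid on this ring would compare also remains open.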